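The source may hold more compounds than are shown below. What is called first, only, known or untested is meant among the compounds shown, and "the series" means these compounds.

Compound 1 `O=c1[nH]c(=S)ccn1[C@@H]1O[C@H](COP(=O)(O)O)[C@@H](O)[C@H]1O` in an in vitro functional assay on 1321-N1 cells for agonist activity at P2Y purinoceptor 4 (Homo sapiens), read by scintillation proximity assay and inositol phosphate accumulation (a higher number here means that more compound is needed for the effect, a lower number that less compound is needed), sits at the limit of the assay, > 100000 nM, and gives no number. Compound 2 `CSc1nc(=O)ccn1[C@@H]1O[C@H](COP(=O)(O)OP(=O)(O)O)[C@@H](O)[C@H]1O` gives 1520 nM in this assay. For the measured compounds named here, compound 3 `CCSc1nc(=O)ccn1[C@@H]1O[C@H](COP(=O)(O)O)[C@@H](O)[C@H]1O` gives 4330 nM, the higher of the two numbers so far, compound 2 standing at the lower one. Compound 4 `CNc1nc(=O)ccn1[C@@H]1O[C@H](COP(=O)(O)O)[C@@H](O)[C@H]1O` has not yet been measured. It differs from compound 3 by methylamino in place of ethylsulfanyl on an aromatic carbon. Going by the values given here, no measured pair shows this change, so the expected step from the ethylsulfanyl to the methylamino compound is taken as small and towards a somewhat higher number, a 1.8-fold higher number from compound 3 to compound 4 (0.27 log units; within the scatter). On that basis compound 4 is expected to give about 8000 nM in this assay, within a range of 2000 nM to 40000 nM.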

Compound 4, half-maximal effective concentration: > 100000 nM
Compound 4 was reported as a limit (the forecaster's own chance of this, stated with the estimate: 25%); at least 12-fold (1.09 log units) between middle value and limit.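

Methylamino in place of ethylsulfanyl, on an aromatic carbon between two ring nitrogen atoms, gives the first step that can be read at this position in this assay, and it is large: an at least 23-fold higher number from compound 3 to compound 4 (1.36 log units; beyond the scatter). The exchange of one small group for another here is therefore not neutral, since compound 3 gives a number and compound 4 does not. Compound 4 stands at a limit, so the step has no upper bound: the limit of > 100000 nM in this assay, at which 2 of the 4 values shown sit.

The compounds shown leave open how a methoxy group, an ethylamino group or a longer chain such as propylsulfanyl would behave at this position. They also leave open whether the sulfur or the chain carries the difference.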